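Imidazoline series: replacing the pyrimidine with furan

This account rests on a few compounds, and the source may have more. Where it says the series, first, only, none or still open, it means among the compounds named here.

Measured so far in a functional assay for activation of Alpha-1B adrenergic receptor (Homo sapiens), read by calcium flux; a higher number here means that more compound is needed for the effect, a lower number that less compound is needed:
Compound 1 `c1cncc(-c2ccccc2OCC2=NCCN2)c1` gives 79.4 nM.
Compound 2 `c1cnc(-c2ccccc2OCC2=NCCN2)nc1` gives only a limit of this assay, < 100000 nM.
Compound 3 `c1ccc(-c2ccncn2)c(OCC2=NCCN2)c1` gives only a limit of this assay, < 100000 nM.

Compound 3 thus stands at a limit and not at a number, and the same limit holds for a second value in the set (the limit of < 100000 nM in this assay, at which 2 of the 3 values shown sit). Compound 4 `c1coc(-c2ccccc2OCC2=NCCN2)c1` differs from compound 3 in one place: furan-2-yl in place of pyrimidin-4-yl on an aromatic carbon. Of the measured steps, those touching compound 3 are a step that the limit leaves unreadable from compound 1 to compound 3 and a step that the two limits leave unreadable from compound 2 to compound 3, and the remaining step that the limit leaves unreadable from compound 1 to compound 2 is equally unreadable. Among the measured compounds shown here, no measured step therefore supplies a size for the change to compound 4, and the expectation rests only on the span of the three measured compounds. Compound 4 is expected to give 400 nM, in the range 40 nM to 20000 nM. That estimate means an expected step that the limit leaves unreadable from compound 3 to compound 4.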

Compound 4, half-maximal effective concentration: 10 nM
Compound 4: the middle estimate sits 40-fold (1.60 log units) above what was measured, outside the stated range (below it).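

In this assay, the aromatic carbon now carries a second group with a measurable value, and furan-2-yl, a five-membered aromatic ring with an oxygen and no nitrogen, gives a 7.9-fold lower number from compound 1 to compound 4 (0.90 log units; beyond the scatter). A ring nitrogen is therefore not required here, and pyridin-3-yl is not the upper end of this position. The steps to compound 4 from compound 2 and compound 3 cannot be read: the limit of < 100000 nM in this assay, at which 2 of the 4 values shown sit.

Still open, from the compounds shown here alone, is whether ring size or the hetero atom accounts for the step. Thiophen-2-yl or plain phenyl on this carbon would separate the two.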